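A Methyl for a Methoxy in a Cytotoxicity Series

A few compounds are considered here, and "the series" means these few. Any claim that something is new, unique, unknown or untested is made for them only; others in the source may bear on it.

Measured compounds:
compound 1 `COc1ccc(-c2cn(C[C@H]3c4c(ccc(O)c4C)[C@@H]4CC[C@@]5(C)C[C@]43CC5=O)nn2)cc1` — > 20000 nM
compound 2 `Cc1ccc(S(=O)(=O)Oc2ccc3c(c2C)[C@H](Cn2cc(-c4ccc(Br)cc4)nn2)[C@@]24CC(=O)[C@@](C)(CC[C@@H]32)C4)cc1` — > 20000 nM
compound 3 `C=C1C[C@]23C[C@@]1(O)CC[C@@H]2c1cccc(C)c1[C@@H]3Cn1cc(-c2ccc(OC)cc2)nn1` — > 20000 nM

The account follows the step from compound 1 to compound 4 in a functional assay on A549 cells (Homo sapiens) for cytotoxicity, read by MTT assay, with a stated time of 4 days; a higher number here means a weaker inhibitor, a lower number a stronger inhibitor. In this assay compound 1 gives > 20000 nM, which is a limit of the assay and not a number. Compound 2 gives > 20000 nM, likewise a limit. Compound 3 gives > 20000 nM, again a limit. All three measured compounds therefore sit at the limit of > 20000 nM in this assay, at which 3 of the 3 values shown sit, so compound 1 cannot be ranked against the others: the numbers shown only say that none of them reaches a measurable half-maximal inhibitory concentration.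

Compound 4 `Cc1ccc(-c2cn(C[C@H]3c4c(ccc(O)c4C)[C@@H]4CC[C@@]5(C)C[C@]43CC5=O)nn2)cc1` is not yet measured. It differs from compound 1 in one place: methyl in place of methoxy on an aromatic carbon.

No step between measured compounds is available for the change described, so nothing among the shown values lets a movement be inferred. The step from compound 1 to compound 4, a step that the limit leaves unreadable from compound 1 to compound 4, is expected to be none beyond the usual scatter. Compound 4 is therefore estimated at 25000 nM, with a range from 8000 nM to 80000 nM, and the assay is expected most likely to report only a limit again for compound 4.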

Compound 4, half-maximal inhibitory concentration: > 20000 nM
Compound 4: only a limit was reported; the forecaster's own chance of this, stated with the estimate: 80%; the middle value lies beyond the limit too.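

In this assay compound 4 gives > 20000 nM, which is a limit of the assay and not a number. For the compounds shown here, compound 1 carries the same kind of limit, so no step from compound 1 to compound 4 can be read: the limit of > 20000 nM in this assay, at which 4 of the 4 values shown sit. The compounds shown leave open whether methyl in place of methoxy changes cytotoxicity at all.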